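Swapping the para halogen on an ester-linked caffeoyl triazole

A few compounds are considered here, and "the series" means these few. Any claim that something is new, unique, unknown or untested is made for them only; others in the source may bear on it.

Compound 1 `CC(=O)Oc1ccc(/C=C/C(=O)OCCCSc2nc(-c3ccc(S(C)(=O)=O)cc3)n(-c3ccc(Br)cc3)n2)cc1OC(C)=O` and compound 2 `CC(=O)Oc1ccc(/C=C/C(=O)NCCCSc2nc(-c3ccc(S(C)(=O)=O)cc3)n(-c3ccc(Br)cc3)n2)cc1OC(C)=O` share a core and differ only in the linker between the cinnamoyl group and the three-carbon chain, an ester in compound 1 and an amide in compound 2. In a functional assay on A549 cells (Homo sapiens) for antiproliferative activity, read by MTT assay, with a stated time of 72 h (a lower number here means a stronger inhibitor, a higher number a weaker inhibitor), compound 1 gives 12900 nM. In this assay compound 2 gives 23300 nM. These two numbers lie within the usual scatter of each other, so nothing can be read into their gap.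

Compound 3 `CC(=O)Oc1ccc(/C=C/C(=O)NCCCSc2nc(-c3ccc(S(C)(=O)=O)cc3)n(-c3ccc(F)cc3)n2)cc1OC(C)=O` is the next step from compound 2. The change is small: fluoro in place of bromo on an aromatic carbon, so the 4-bromophenyl on the triazole nitrogen becomes a 4-fluorophenyl. Among the compounds with values here, no measured pair shows this exchange, so there is nothing to lean on for its size or direction.

The expectation is therefore a modest step, possibly toward a somewhat weaker inhibitor, with the change from compound 2 to compound 3 in this assay estimated as a 1.1-fold higher number from compound 2 to compound 3 (0.05 log units; within the scatter). Compound 3 is expected to give about 26000 nM in this assay, in a range from 10000 nM to 65000 nM.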

Compound 3, half-maximal inhibitory concentration: 21800 nM
Beside the measured number, compound 3's estimate is 1.2-fold (0.08 log units) above it, and the stated range covers the measured number.
By their numbers in this assay, from the lowest: compounds 1, 3 and 2 (each within the scatter of the next).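

In this assay, within the data shown here, the exchange of 4-bromophenyl for 4-fluorophenyl is the only measured pair at this position, and it gives a 1.1-fold lower number from compound 2 to compound 3 (0.03 log units; within the scatter), a step within the scatter. On the amide-linked core of compound 2, bromo and fluoro on this aromatic carbon, para to a large group, therefore cannot be told apart in this read-out, so this one pair gives no sign that the choice between these two halogens matters here. Nothing measured here offers an explanation for this result.

From the compounds shown here alone, the step rests on a single pair, so it remains open whether the same exchange would read alike on the ester-linked compound 1, where the linker differs. Also open, going by these compounds, is whether a non-halogen group at this position, such as a methoxy group, an amine or a carboxylic acid, or a longer chain elsewhere in the molecule, would move the number in this assay beyond the scatter.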